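This account rests on a few compounds, and the source may have more. Where it says the series, first, only, none or still open, it means among the compounds named here.

Series notes. Compound 3 `CC(Sc1nc2c(cnn2C)c(=O)n1-c1ccc(CN)cc1)c1ccccc1` is the reference point. In an assay on isolated protein for inhibition of retinal dehydrogenase 2 (Homo sapiens), tested at 5 uM (on this read-out higher numbers stand for more inhibition at the one concentration tested (going by the name of the read-out) and lower numbers for less inhibition), compound 3 gives 64%, the second highest of the three numbers; compound 1 `CC(Sc1nc2c(cnn2C)c(=O)n1-c1ccccc1)c1ccncc1` gives 69%, within the scatter of compound 3, while compound 2 `COc1ccc(C(C)Sc2nc3c(cnn3C)c(=O)n2-c2ccccc2)cc1` gives 41%, beyond the scatter below it. For the measured compounds named here, the only single-place step measured, a number 28 percentage points lower from compound 1 to compound 2 (beyond the scatter), concerns a change on the chain carbon bound to sulfur and not the amine, so nothing measured bears directly on the present step. Compound 4 `CNCc1ccc(-n2c(SC(C)c3ccccc3)nc3c(cnn3C)c2=O)cc1` differs from compound 3 in one place: methyl in place of hydrogen on an amine nitrogen. Going by the values given here, with no comparable step in hand, no change beyond the scatter is expected in this assay, and the step is estimated as a number 4 percentage points lower from compound 3 to compound 4 (within the scatter). Compound 4 is therefore expected to give about 60%, within 42% to 76%.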

Compound 4, a percentage reported as inhibition, at one concentration (the size of the read-out at that concentration, not a potency): 70%
For compound 4 the middle estimate is 10 percentage points below the measured one; the measured number falls inside the stated range.
By their numbers in this assay, from the lowest: compound 2; then compounds 3, 1 and 4 (each within the scatter of the next).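

In this assay, for the compounds shown here, methyl in place of hydrogen on an amine nitrogen gives a number 6 percentage points higher from compound 3 to compound 4 (within the scatter), the first measured change at this position, so the 4-(aminomethyl)phenyl group accepts this single methyl without a shift beyond the scatter. Nothing available explains this result. As far as these compounds go, whether the same position accepts a larger or different group, such as dimethylamino, ethylamino or an acetamide, remains open. The compounds shown also leave open what the aminomethyl group itself contributes, since none isolates it from the other differences in the series.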